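Notes on the hydroxy analogue of compound 3

This account rests on a few compounds, and the source may have more. Where it says the series, first, only, none or still open, it means among the compounds named here.

Measured compounds in a functional assay on NCI-H460 cells (Homo sapiens) for inhibition, read by sulforhodamine B assay, with a stated time of 48 h; a higher number here means a weaker inhibitor of growth, a lower number a stronger inhibitor of growth:
compound 1 `O=C(Nc1cccc(-n2cc(-c3ccncc3)c(-c3ccc(Cl)c(O)c3)n2)c1)Nc1cccc(C(F)(F)F)c1`: 29000 nM
compound 2 `O=C(Nc1cccc(-n2cc(-c3ccncc3)c(-c3ccc(Cl)c(O)c3)n2)c1)Nc1ccc(Cl)c(Cl)c1`: 3570 nM
compound 3 `COc1cc(-c2nn(-c3cccc(NC(=O)Nc4ccc(Cl)c(C(F)(F)F)c4)c3)cc2-c2ccncc2)ccc1Cl`: 4790 nM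

Compound 3 stands second highest of the three numbers in this assay; its nearest neighbour is compound 2, within the scatter, and its furthest is compound 1, beyond it. Compound 4 `O=C(Nc1cccc(-n2cc(-c3ccncc3)c(-c3ccc(Cl)c(O)c3)n2)c1)Nc1ccc(Cl)c(C(F)(F)F)c1` is the unmeasured phenol analogue of compound 3: the difference is hydrogen in place of methyl on an oxygen on an aromatic ring, which cut one bond further out reads methoxy to hydroxy, 4-chloro-3-methoxyphenyl to 4-chloro-3-hydroxyphenyl.

Going by the values given here, the one measured step, an 8.1-fold lower number from compound 1 to compound 2 (0.91 log units; beyond the scatter), concerns the urea aryl group and not the oxygen, so no step here bears directly on the change. Compounds 1 and 2 both carry the hydroxy group that enters in compound 4, and their values frame what the hydroxy-bearing shared core can give. The hydroxy change is therefore expected to yield no step beyond the scatter; the expected step is a 1.2-fold lower number from compound 3 to compound 4 (0.08 log units; within the scatter). Compound 4 is estimated at 4000 nM, with a range from 1500 nM to 12000 nM.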

Compound 4, concentration for total growth inhibition: 4000 nM
Compound 4: the middle estimate sits on the measured number at the digits printed, within the range that was stated.
By their numbers in this assay, from the lowest: compounds 2, 4 and 3 (each within the scatter of the next); then compound 1.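

In this assay, going by these compounds alone, methoxy to hydroxy on the 4-chloro-3-methoxyphenyl group gives (a 1.2-fold lower number from compound 3 to compound 4 (0.08 log units; within the scatter)), the first direct reading of this change, and at this position the pair does not separate the two groups. With the hydroxy group held in place, trifluoromethyl in place of chloro on an aromatic carbon of the urea aryl group gives (a 1.1-fold higher number from compound 2 to compound 4 (0.05 log units; within the scatter)), whereas chloro in place of hydrogen gives (a 7.3-fold lower number from compound 1 to compound 4 (0.86 log units; beyond the scatter)), so among these phenols only the hydrogen-bearing compound 1 stands apart. Nothing in hand gives a reason for either the flat pair or the larger step.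

Going by these compounds, whether an ethyl group or a longer chain on this oxygen, or an amine in place of the oxygen, would read the same remains open. So does whether methoxy to hydroxy stays within the scatter with the urea aryl groups of compound 1 and compound 2.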